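A Trifluoromethyl Analogue Awaiting Its Cytotoxicity Reading

The source may hold more compounds than are shown below. What is called first, only, known or untested is meant among the compounds shown, and "the series" means these compounds.

Compound 1, `Cc1ccc2c(c1)[n+]([O-])c(C(=O)NCc1ccccc1)c(C)[n+]2[O-]`: in an ADME assay on Vero cells (Chlorocebus sabaeus) for cytotoxicity, read by MTT assay, with a stated time of 72 h (on this read-out higher numbers stand for weaker inhibition and lower numbers for stronger inhibition), compound 1 gives > 100 ug/mL, which is a limit of the assay and not a number.
Compound 2, `COc1ccc2c(c1)[n+]([O-])c(C(=O)NCc1ccccc1)c(C)[n+]2[O-]`: in this assay compound 2 gives "not determined" (no result reported).

Compound 2 therefore has no single number in this assay. Among the compounds with values here, the only further value shown for the series is a limit, (the limit of > 100 ug/mL in this assay, at which 1 of the 2 values shown sits), so nothing measured tells how compound 2 compares with compound 1.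

Compound 3, `Cc1c(C(=O)NCc2ccccc2)[n+]([O-])c2cc(C(F)(F)F)ccc2[n+]1[O-]`, has yet to be measured in this assay. It differs from compound 2 in one place: trifluoromethyl in place of methoxy on an aromatic carbon. Within the data shown here, no step between measured compounds is available, so no measured size of change can be pointed to. Among the measured compounds shown here, the one value shown, (the limit of > 100 ug/mL in this assay, at which 1 of the 2 values shown sits), sits at the limit, and the expectation for compound 3 is a step of no more than the usual scatter, in no particular direction, with a fair chance that the assay again reports only a limit.

Compound 3 is expected to give about 90 ug/mL, with a likely range from 35 ug/mL to 200 ug/mL.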

Compound 3, half-maximal inhibitory concentration: > 100 ug/mL
Compound 3: only a limit was reported; the forecaster's own chance of this, stated with the estimate: 60%; middle value at least 1.1-fold (0.04 log units) from the limit.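

In this assay compound 3 gives > 100 ug/mL, which is a limit of the assay and not a number. Within the data shown here, no step from compound 1 to compound 3 can be read, because both compounds stand at that limit: the limit of > 100 ug/mL in this assay, at which 2 of the 3 values shown sit. The compounds shown leave open how strongly, if at all, any of them inhibits in this assay and where compound 2 stands.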